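Aryl amide swap to pyridin-3-yl: clearance notes

The source may report more compounds than this note shows. Statements on the series, on what has been measured and on what is new or still open speak of the compounds shown alone.

Measured compounds:
compound 1 `Cc1ccc(NC(=O)[C@H]2CN(C)C[C@@H]2c2ccc(/C=C/C(=O)Nc3ccccc3N)cc2)cc1` – 15 mL/min/kg
compound 2 `COc1cccc(NC(=O)[C@H]2CN(C)C[C@@H]2c2ccc(/C=C/C(=O)Nc3ccccc3N)cc2)c1` – 14 mL/min/kg

Both were run in an in vitro ADME assay on microsomes from liver (Homo sapiens) for pharmacokinetics, read by LC-MS, with a stated time of 10 min, tested at 1 uM; on this read-out higher numbers stand for fast clearance and lower numbers for slow clearance. Compound 2 stands lowest of the two numbers, and its nearest neighbour is compound 1; the step of a 1.1-fold lower number from compound 1 to compound 2 (0.03 log units; within the scatter) lies within the scatter, so the two values cannot be put in order.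

The unmeasured compound 3 `CN1C[C@H](C(=O)Nc2cccnc2)[C@@H](c2ccc(/C=C/C(=O)Nc3ccccc3N)cc2)C1` differs from compound 2 at one place: pyridin-3-yl in place of 3-methoxyphenyl on an amide-type nitrogen. Among the measured compounds shown here, only one measured step exists, a 1.1-fold lower number from compound 1 to compound 2 (0.03 log units; within the scatter), and it also exchanged the aryl group on the same amide-type nitrogen without moving the number beyond the scatter. For the measured compounds named here, no measured step exchanges a phenyl for a pyridin-3-yl, so the expectation rests on that single step alone. The change from compound 2 to compound 3 is therefore expected to give no step beyond the scatter in this assay, no change at the digits printed from compound 2 to compound 3 (within the scatter). Compound 3 is estimated at 14 mL/min/kg, with the expected range running from 7 mL/min/kg to 28 mL/min/kg.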

Compound 3, clearance: 10 mL/min/kg
Estimate against measurement, compound 3: 1.4-fold (0.15 log units) above, within the range that was stated.
By their numbers in this assay, from the lowest: compounds 3, 2 and 1 (each within the scatter of the next).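

In this assay the amide-type nitrogen now carries a six-membered aromatic ring with a hetero atom, and the swap of pyridin-3-yl for 3-methoxyphenyl gives a 1.4-fold lower number from compound 2 to compound 3 (0.15 log units; within the scatter) and stays inside the usual variation of repeated measurements. The swap of pyridin-3-yl for 4-methylphenyl at the same nitrogen gives a 1.5-fold lower number from compound 1 to compound 3 (0.18 log units; within the scatter) and reads the same way, so the three aryl groups seen here cannot be put in order, whereas the earlier pair covered only rings of carbon. No supporting data bear on why the numbers fall as they do.

Open, as far as these compounds go, is whether a group of another kind on this nitrogen, such as a cyclohexyl ring, a longer alkyl chain, or an aryl ring bearing a carboxylic acid or an amine, would give a step beyond the scatter in this assay. Also open, from the compounds shown here alone, is whether pyridin-2-yl or pyridin-4-yl would read like pyridin-3-yl, and whether changes elsewhere on the shared core would move the clearance more than any exchange at this nitrogen.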